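The source may report more compounds than this note shows. Statements on the series, on what has been measured and on what is new or still open speak of the compounds shown alone.

Compound 1 `CC(C)[C@H](C(=O)NO)N(CCn1cc(CCCF)nn1)S(=O)(=O)c1ccc(OCCF)cc1`, 2 nM
Compound 2 `CC(C)[C@H](C(=O)NO)N(CCn1cc(CCCCOc2cccnc2F)nn1)S(=O)(=O)c1ccc(OCCF)cc1`, 0.8 nM
Compound 3 `CC(C)[C@H](C(=O)NO)N(CCn1cc(CNS(=O)(=O)c2ccc(F)cc2)nn1)S(=O)(=O)c1ccc(OCCF)cc1`, 3 nM

These three share one core and differ only at the end of one side chain. In an assay on isolated protein for inhibition of matrix metalloproteinase-9 (Homo sapiens), read by fluorescence, with a stated time of 30 min (a lower number here means a stronger inhibitor, a higher number a weaker inhibitor), compound 3 gives the highest of the three numbers, yet compound 1 is close, the step of a 1.5-fold higher number from compound 1 to compound 3 (0.18 log units; within the scatter) lying within the scatter; compound 2 stands further away, the step of a 3.8-fold higher number from compound 2 to compound 3 (0.57 log units; beyond the scatter) being beyond it. Compound 4 `CC(C)[C@H](C(=O)NO)N(CCn1cc(CN(C)S(=O)(=O)c2ccc(F)cc2)nn1)S(=O)(=O)c1ccc(OCCF)cc1` is not yet measured and differs from compound 3 by methyl in place of hydrogen on a sulfonamide nitrogen. Among the measured compounds shown here, no measured step touches this nitrogen: the steps of a 2.5-fold lower number from compound 1 to compound 2 (0.40 log units; beyond the scatter) and those just named all rework the chain end, and the one that introduced the sulfonamide stayed within the scatter. A change within the scatter is therefore expected, no change at the digits printed from compound 3 to compound 4 (within the scatter). Compound 4 is expected to give 3 nM in this assay, between 1.5 nM and 7 nM.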

Compound 4, half-maximal inhibitory concentration: 11 nM
Estimate against measurement, compound 4: 3.7-fold (0.56 log units) below; measured number outside the range, above it.
By their numbers in this assay, from the lowest: compound 2; then compounds 1 and 3 (each within the scatter of the next); then compound 4.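

A single methyl on the sulfonamide nitrogen gives a 3.7-fold higher number from compound 3 to compound 4 (0.56 log units; beyond the scatter) and so does more than the change that brought the sulfonamide in, which stayed within the scatter. That one carbon also opens a gap to the other chain ends, seen in a 5.5-fold higher number from compound 1 to compound 4 (0.74 log units; beyond the scatter) and a 14-fold higher number from compound 2 to compound 4 (1.14 log units; beyond the scatter) even though compound 3 stays within the scatter of compound 1. No measurement here bears on why the number rises.

On these data alone, whether an ethyl group on this nitrogen would raise the number further stays open. So does whether the methyl has a step of this size when another group replaces the 4-fluorophenyl.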